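Methyl position on the aryl urea of compound 1

The compounds below may be only part of what the source reports. "The series", "measured", "known", "first", "only" and "open" are said of these compounds alone.

Compound 1 `Cc1ccc(NC(=O)N[C@H]2CC[C@H](Oc3ccc(F)cc3)CC2)cc1` carries the 4-methylphenyl group on the urea nitrogen. In a functional assay on CRL2813 cells (Homo sapiens) for cytotoxicity, read by sulforhodamine B assay, with a stated time of 5 days (a lower number here means a stronger inhibitor, a higher number a weaker inhibitor), compound 1 gives > 20000 nM, which is a limit of the assay and not a number (the limit of > 20000 nM in this assay, at which 1 of the 2 values shown sits). Compound 2 `Cc1cccc(NC(=O)N[C@H]2CC[C@H](Oc3ccc(F)cc3)CC2)c1` shifts the methyl; in this assay compound 2 gives 14400 nM, and the step of an at least 1.3-fold lower number from compound 1 to compound 2 (0.14 log units; that floor lies within the scatter) stays within the scatter. Compound 3 `Cc1ccccc1NC(=O)N[C@H]1CC[C@H](Oc2ccc(F)cc2)CC1` is the remaining isomer: 2-methylphenyl in place of 4-methylphenyl on an amide-type nitrogen. Going by the values given here, the only measured step that bears on this change is the one from compound 1 to compound 2, and it was small. For compound 3 a step no larger than the scatter is therefore expected, a number no higher from compound 1 to compound 3 (the limit leaves the size open). Compound 3 is estimated at 20000 nM, ranging from 8000 nM to 50000 nM.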

Compound 3, half-maximal inhibitory concentration: > 20000 nM
Compound 3: a limit, no number; the forecaster's own chance of this, stated with the estimate: 55%; the middle value sits exactly at the limit.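

In this assay compound 3 also ends at a limit rather than a number, so moving the methyl to give 2-methylphenyl yields no measurable cytotoxicity value: the limit of > 20000 nM in this assay, at which 2 of the 3 values shown sit.

Going by these compounds alone, the one readable step, an at least 1.3-fold higher number from compound 2 to compound 3 (0.14 log units; that floor lies within the scatter), does not separate the two compounds. The step from compound 1 to compound 3 cannot be read, since both values are limits.

From the compounds shown here alone, whether methyl position matters at all remains open. A carboxylic acid or an amine in place of the methyl could show whether this aryl group can shift the number in this assay.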